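Moving from compound 3 to a dimethoxyphenyl ketone

A few compounds are considered here, and "the series" means these few. Any claim that something is new, unique, unknown or untested is made for them only; others in the source may bear on it.

Compound 1 `COc1ccc(-c2cc3ccccc3nc2/C=C/C(=O)c2ccc(F)cc2)cc1` in a functional assay on H184B5F5/M10 cells (Homo sapiens) for antiproliferative activity, read by XTT assay, with a stated time of 72 h (a higher number here means a weaker inhibitor, a lower number a stronger inhibitor), gives > 10000 nM, which is a limit of the assay and not a number. Compound 2 `COc1ccc(-c2cc3ccccc3nc2/C=C/C(=O)c2ccc(O)cc2)cc1` in this assay gives 5690 nM. Compound 3 `COc1ccc(C(=O)/C=C/c2nc3ccccc3cc2-c2ccc(OC)cc2)cc1` in this assay gives > 10000 nM, again a limit of the assay.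

Compound 3 therefore stands at the top of the measured range, at the same limit as compound 1 (the limit of > 10000 nM in this assay, at which 2 of the 3 values shown sit); only compound 2 returns a number. The step of an at least 1.7-fold higher number from compound 2 to compound 3 (0.24 log units; that floor lies within the scatter) is known only as a floor, and the step that the two limits leave unreadable from compound 1 to compound 3 cannot be read because both ends are limits. Compound 4 `COc1ccc(-c2cc3ccccc3nc2/C=C/C(=O)c2c(OC)cccc2OC)cc1` differs from compound 3 by 2,6-dimethoxyphenyl in place of 4-methoxyphenyl on a carbonyl carbon. For the measured compounds named here, all three measured steps alter substituents on that same ring attached to the carbonyl carbon, and two of the three variants sit at the limit, so the only reading available is that this ring tolerates little without losing a measurable number. The step that the limit leaves unreadable from compound 3 to compound 4 is therefore expected to be none beyond the scatter, most likely leaving compound 4 at the limit. Compound 4 is estimated at 15000 nM, within 5000 nM to 50000 nM.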

Compound 4, half-maximal inhibitory concentration: 4470 nM
For compound 4 the middle estimate is 3.4-fold (0.53 log units) above the measured one; measured number outside the range, below it.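

In this assay, for the compounds shown here, the change at the carbonyl carbon gives an at least 2.2-fold lower number from compound 3 to compound 4 (0.34 log units; beyond the scatter), and the comparison with the fluoro compound gives an at least 2.2-fold lower number from compound 1 to compound 4 (0.34 log units; beyond the scatter), so the ring at this place can carry methoxy groups and still return a measurable number, which the single methoxy group of compound 3 did not show. The comparison with the hydroxy compound gives a 1.3-fold lower number from compound 2 to compound 4 (0.10 log units; within the scatter), so 2,6-dimethoxyphenyl and 4-hydroxyphenyl cannot be told apart here, and a hydroxy group is not the only route to a measurable number. Compound 1 and compound 3 each remain at a limit of the assay, not a number: the limit of > 10000 nM in this assay, at which 2 of the 4 values shown sit.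

The compounds shown leave open whether both methoxy groups of 2,6-dimethoxyphenyl are needed for this result. They also leave open how an amine or a carboxylic acid on this ring would read out.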